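From compound 2 to compound 4: dropping a chloro group

The source may hold more compounds than are shown below. What is called first, only, known or untested is meant among the compounds shown, and "the series" means these compounds.

Measured so far:
- compound 1, `COc1cc(O)c(C(=O)/C=C/c2ccc(F)cc2)c(OC)c1`: "not active" (no number reported)
- compound 2, `COc1cc(OC)c(C(=O)/C=C/c2ccc(Cl)cc2)c(OC)c1`: 40%
- compound 3, `COc1cccc(/C=C/C(=O)c2c(O)cc(OC)cc2OC)c1`: 35%

In a functional assay on NCI-H727 cells (Homo sapiens), read by fluorescence and BrdU incorporation, with a stated time of 48 h, tested at 10 uM (a higher number here means a weaker effect of the compound at the concentration tested, a lower number a stronger effect), compound 1 gave no number at all, only the report that it was not active. The two compounds with a number stand close together: compound 2 gives 40%, and compound 3 gives 35%, a gap that lies within the usual scatter of repeated measurements, so neither can be called the stronger of the two. Compound 2 is therefore one of two similar numbers, with one further entry that has no number.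

The next compound, compound 4, `COc1cc(OC)c(C(=O)/C=C/c2ccccc2)c(OC)c1`, has not yet been measured. It differs from compound 2 in a single place:

hydrogen in place of chloro on an aromatic carbon

For the measured compounds named here, no measured pair in this set shows what this kind of change does in this assay, so there is no step to lean on. With only compound 2 and compound 3 as neighbours, the expectation for compound 4 is a modest move toward a weaker effect, a shift of a number 10 percentage points higher from compound 2 to compound 4 (within the scatter), though a result within the scatter of compound 2 would not be surprising. Compound 4 is estimated to give 50%, within a range from 30% to 75%.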

Compound 4, a percentage reported as activity, at one concentration (the size of the read-out at that concentration, not a potency): 34%
Compound 4: the middle estimate sits 16 percentage points above what was measured, and the stated range covers the measured number.
By their numbers in this assay, from the lowest: compounds 4, 3 and 2 (each within the scatter of the next).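

For the compounds shown here, this is the first pair in the set that differs in one place, and it gives a direct reading of this position in this assay: replacing chloro with hydrogen, which turns the 4-chlorophenyl into a phenyl, gives a number 6 percentage points lower from compound 2 to compound 4 (within the scatter). On this aromatic carbon, para to a large group, the chloro group is therefore not needed for the effect seen at the concentration tested, since the two compounds cannot be told apart within the usual scatter. Nothing available here offers an explanation for this result.

The compounds shown leave open whether this position stays as tolerant with a group of a different kind, such as an amine, a carboxylic acid or a longer chain like butyl, on the same carbon; any of these could stay within the scatter of compound 4 or move clearly away from it. From the compounds shown here alone, it also remains open whether the same closeness would hold in a full concentration series, since a read-out at one concentration is not a potency.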